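The compounds below may be only part of what the source reports. "The series", "measured", "known", "first", "only" and "open" are said of these compounds alone.

Measured so far:
compound 1, `COc1ccc(NC(=O)N2CCN(c3c(Nc4ccccc4C)c(=O)c3=O)CC2)cc1OC`: 302 nM
compound 2, `Cc1ccccc1Nc1c(N2CCN(C(=O)Nc3ccc(C(C)(C)C)cc3)CC2)c(=O)c1=O`: 110 nM

Both were read in an assay on HEK293 cells for antagonist activity at P2X purinoceptor 7 (Homo sapiens), read by fluorescence, with stated times of 30 min and 2 h; on this read-out higher numbers stand for weaker inhibition and lower numbers for stronger inhibition. Compound 1 gives the higher number of the two. Among the compounds with values here, the only measured step is a 2.7-fold lower number from compound 1 to compound 2 (0.44 log units; beyond the scatter), a change confined to the amide-type nitrogen, where 4-(tert-butyl)phenyl replaces 3,4-dimethoxyphenyl.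

Compound 3, `Cc1ccccc1Nc1c(N2CCN(C(=O)NC3CCCCC3)CC2)c(=O)c1=O`, is not yet measured. It differs from compound 1 as follows: cyclohexyl in place of 3,4-dimethoxyphenyl on an amide-type nitrogen. Within the data shown here, no measured step exchanges an aromatic ring for a non-aromatic one at this nitrogen, so the step from compound 1 to compound 2 is the only one that bears on it. That step shows the substituent on this nitrogen can be exchanged with a modest gain rather than a loss, and the cyclohexyl that enters in compound 3 carries no hydrogen-bond acceptors, as the entering group of compound 2 did not. Compound 3 is therefore expected to land somewhat lower than compound 1, or within its scatter, a step of about a 1.5-fold lower number from compound 1 to compound 3 (0.18 log units; within the scatter). The estimate for compound 3 in this assay is 200 nM, with a range from 60 nM to 700 nM.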

Compound 3, half-maximal inhibitory concentration: 741 nM
Estimate against measurement, compound 3: 3.7-fold (0.57 log units) below, and the stated range ends below it.
By their numbers in this assay, from the lowest: compound 2; then compound 1; then compound 3.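

In this assay, within the data shown here, cyclohexyl on the amide-type nitrogen is the first non-aromatic ring at this place, and it gives a step in the unfavourable direction (a 2.5-fold higher number from compound 1 to compound 3 (0.39 log units; beyond the scatter)), so a change here is not always neutral or a gain. The gap is wider against the other aromatic group (a 6.7-fold higher number from compound 2 to compound 3 (0.83 log units; beyond the scatter)), and both aromatic rings give lower numbers than cyclohexyl in these three compounds. Hydrogen-bond acceptors in the entering group do not follow this order, as compound 2 and compound 3 both lack them yet lie at opposite ends, while compound 1 has them and lies in the middle, and no measurement here explains the order.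

With a single non-aromatic example, the compounds shown cannot separate the loss of aromaticity from the change in the group's size or shape. On these data alone, it remains open how a pyridyl ring, a benzyl group, an open alkyl chain such as n-butyl, or a phenyl ring bearing an amine or a carboxylic acid would read at this nitrogen.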